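The source may hold more compounds than are shown below. What is called first, only, known or untested is meant among the compounds shown, and "the series" means these compounds.

Within the data shown here, compound 2, whose structure is `O=S1(=O)CC(Nc2nonc2/C(=N/O)Nc2ccc(F)c(Br)c2)C1`, is the one compound here with a measured number: in an assay on HeLa cells for inhibition of Indoleamine 2,3-dioxygenase 1 (Homo sapiens), read by spectrophotometry, with a stated time of 24 h (a higher number here means that more compound is needed for the effect, a lower number that less compound is needed), compound 2 gives 59 nM. Compound 1, whose structure is `CS(=O)(=O)NNc1nonc1/C(=N/O)Nc1ccc(F)c(Br)c1`, gives in this assay only a limit of the assay, > 800 nM. The step between them, an at least 13-fold lower number from compound 1 to compound 2 (1.13 log units; beyond the scatter), rests on (the limit of > 800 nM in this assay, at which 1 of the 2 values shown sits). Compound 3, whose structure is `CN(C)S(=O)(=O)CCNc1nonc1/C(=N/O)Nc1ccc(F)c(Br)c1`, differs from compound 2 by a group of 8 heavy atoms (4 carbon, 1 nitrogen, 2 oxygen, 1 sulfur; no ring) in place of a group of 6 heavy atoms (3 carbon, 2 oxygen, 1 sulfur; one four-membered non-aromatic ring with 1 hetero atom), on a nitrogen on an aromatic ring. Among the measured compounds shown here, the one measured step also changed the group on this same nitrogen, and it was large, but it ran from a limit to a number and so sets no clear expectation for a second swap. A moderate change in either direction is possible, with a small loss seen as somewhat more likely. The expected step is a 1.9-fold higher number from compound 2 to compound 3 (0.27 log units; within the scatter). For compound 3 the estimate in this assay is 110 nM, within a range from 30 nM to 450 nM.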

Compound 3, half-maximal effective concentration: 17 nM
Estimate against measurement, compound 3: 6.5-fold (0.81 log units) above; the measured number lies below the stated range.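

The open chain 2-(dimethylsulfamoyl)ethyl on this nitrogen gives a 3.5-fold lower number from compound 2 to compound 3 (0.54 log units; beyond the scatter) in this assay, so the four-membered ring of compound 2 is not required for a low number here. Compound 3 also gives an at least 47-fold lower number from compound 1 to compound 3 (1.67 log units; beyond the scatter), which shows that two sulfur-bearing groups on the same nitrogen can behave very differently, with methanesulfonamido in compound 1 the one that goes against the other two. Compound 1 gives only a limit, so this second step has a bound rather than an exact size: the limit of > 800 nM in this assay, at which 1 of the 3 values shown sits.

The compounds shown leave open whether sulfur is needed at all, since a carboxylic acid or an amine at the end of the chain could read either way. They also leave open how a longer chain, or the same ethyl chain without its dimethyl groups, would compare.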